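Methyl on the aromatic ring across two cores

The source may hold more compounds than are shown below. What is called first, only, known or untested is meant among the compounds shown, and "the series" means these compounds.

Measured so far:
compound 1, `C/C(=C\c1cc(-c2cccnc2)co1)C(N)=O`, 8640 nM
compound 2, `C/C(=C\c1cc(-c2ccc(C)nc2)co1)C(N)=O`, > 50000 nM
compound 3, `C/C(=C\c1cc(-c2ccccc2)cs1)C(N)=O`, > 50000 nM

In a functional assay on HO8910 cells (Homo sapiens) for cytotoxicity, read by CCK-8 assay, with a stated time of 24 h (a lower number here means a stronger inhibitor, a higher number a weaker inhibitor), compound 1 gives 8640 nM. For compound 2 this assay returns only a limit, > 50000 nM. The change between them is methyl in place of hydrogen on an aromatic carbon, and it brings an at least 5.7-fold higher number from compound 1 to compound 2 (0.76 log units; beyond the scatter). For compound 3 this assay likewise returns only a limit, > 50000 nM. How the core of compound 3 differs from the core of compound 1 is not broken down here. Two of the three values shown so far are limits rather than numbers, see (the limit of > 50000 nM in this assay, at which 2 of the 3 values shown sit).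

Compound 4, `C/C(=C\c1cc(-c2ccccc2C)cs1)C(N)=O`, is not yet measured. It stands to compound 3 as compound 2 stands to compound 1: methyl in place of hydrogen on an aromatic carbon. This is the same kind of change, not the same one: in compound 2 the methyl sits on a six-membered aromatic ring with 1 nitrogen, next to the ring nitrogen and para to a large group; in compound 4 it sits on a six-membered aromatic ring of carbon only, ortho to a large group.

For compound 4 in this assay the expectation is 70000 nM, between 30000 nM and 150000 nM, most probably again only a limit. Going by the values given here, the expected step that the limit leaves unreadable from compound 3 to compound 4 is small because compound 3 already stands at > 50000 nM, and the one measured example of this kind of change, an at least 5.7-fold higher number from compound 1 to compound 2 (0.76 log units; beyond the scatter), gave no ground to expect a lower number.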

Compound 4, half-maximal inhibitory concentration: 15200 nM
Estimate against measurement, compound 4: 4.6-fold (0.66 log units) above; the whole stated range lies above it.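

In this assay, methyl in place of hydrogen on an aromatic carbon gives an at least 3.2-fold lower number from compound 3 to compound 4 (0.51 log units; beyond the scatter), so the direction of this change does not carry from one core to the other in this series: the same change on two cores in this assay, an at least 5.7-fold higher number (0.76 log units; beyond the scatter) from compound 1 to compound 2 and an at least 3.2-fold lower number (0.51 log units; beyond the scatter) from compound 3 to compound 4, at least 19-fold (1.27 log units) apart, beyond the scatter of two such steps Each of the two steps has a limit at one end, so the direction of each can be read but its true size cannot: the limit of > 50000 nM in this assay, at which 2 of the 4 values shown sit. The two cases also differ in more than the core, since the methyl of compound 4 sits ortho to a large group on a six-membered aromatic ring of carbon only, while that of compound 2 sits on a six-membered aromatic ring with 1 nitrogen, and the pair therefore cannot show whether the core, the ring or the place of the methyl sets the direction.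

Open, on these data alone, is how the methyl behaves on the ring of compound 2 when that ring stands on the core of compound 3, and on the carbon-only ring when it stands on the core of compound 1. Also open, as far as these compounds go, is whether an ethyl, a methoxy or an amine at the place of this methyl would follow the step seen with methyl.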